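The compounds below may be only part of what the source reports. "The series", "measured", "known", "first", "only" and "open" are said of these compounds alone.

Measured in a functional assay on the whole organism with Rattus norvegicus as the target; a lower number here means that less compound is needed, a higher number that more compound is needed for the effect:
Compound 1 `CC(=O)Nc1ccc(C2=NNC(=O)CC2)cc1`: 4 umol/kg
Compound 2 `COc1ccccc1OCC(O)CNCCC(=O)Nc1ccc(C2=NNC(=O)CC2)cc1`: 4.3 umol/kg
Compound 3 `COc1ccccc1OCC(O)CNCCC(=O)Nc1ccc(C2=NNC(=O)CC2C)cc1`: 3 umol/kg

All three values lie within the scatter of one another, so compound 3 at 3 umol/kg stands level with compound 1 and compound 2. Compound 4 `CC1CC(=O)NN=C1c1ccc(NC(=O)CCNCC(O)COc2ccccc2C#N)cc1` carries cyano in place of methoxy on an aromatic carbon, ortho to a large group (cyano in place of methoxy on an aromatic carbon). For the measured compounds named here, no measured step touches this place. The only one, a 1.4-fold lower number from compound 2 to compound 3 (0.16 log units; within the scatter), is a methyl in place of hydrogen on a saturated ring carbon and stays within the scatter. With no evidence for a shift in either direction, the expected step is no change at the digits printed from compound 3 to compound 4 (within the scatter), nothing beyond the scatter. For compound 4 the estimate is 3 umol/kg, with an expected range of 1.2 umol/kg to 7.5 umol/kg.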

Compound 4, dose for half-maximal effect: 2.3 umol/kg
For compound 4 the middle estimate is 1.3-fold (0.12 log units) above the measured one; the range from low to high includes it.
By their numbers in this assay, from the lowest: compounds 4, 3, 1 and 2 (each within the scatter of the next).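

In this assay, cyano in place of methoxy on an aromatic carbon, ortho to a large group, gives a 1.3-fold lower number from compound 3 to compound 4 (0.12 log units; within the scatter) and so shows no shift that can be told from the scatter. At this position, the 2-cyanophenoxy and 2-methoxyphenoxy forms therefore stand level. No evidence on the cause is at hand. Still open, going by these compounds, is whether an amine, a carboxylic acid or chlorine at this place would move the number beyond the scatter. Also open, on these data alone, is whether cyano behaves alike with hydrogen instead of methyl on the saturated ring carbon.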